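Dimethylamino for Chlorine on the Outer Phenyl Ring

The source may report more compounds than this note shows. Statements on the series, on what has been measured and on what is new or still open speak of the compounds shown alone.

Compound 1, `COC(=O)/C=C/c1cccc(N(Cc2ccc(/C=C/c3cccc(C(F)(F)F)c3)cc2)C(=O)C(C)C)c1`: 267 nM
Compound 2, `COC(=O)/C=C/c1cccc(N(Cc2ccc(/C=C/c3ccc(F)cc3)cc2)C(=O)C(C)C)c1`: 120 nM
Compound 3, `COC(=O)/C=C/c1cccc(N(Cc2ccc(-c3cccc(Cl)c3)cc2)C(=O)C(C)C)c1`: 77 nM

In an assay on isolated protein with Bile acid receptor (Homo sapiens) as the target (on this read-out lower numbers stand for an effect already at smaller amounts and higher numbers for an effect only at larger amounts of compound), compound 3 gives the lowest number of the three. Its distance from compound 1 is clear, a 3.5-fold lower number from compound 1 to compound 3 (0.54 log units; beyond the scatter), whereas the step of a 1.6-fold lower number from compound 2 to compound 3 (0.19 log units; within the scatter) lies within the scatter, so compound 2 and compound 3 cannot be ranked against each other. The remaining measured step, a 2.2-fold lower number from compound 1 to compound 2 (0.35 log units; beyond the scatter), concerns the ring at the far end of the two-carbon bridge.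

Compound 4, `COC(=O)/C=C/c1cccc(N(Cc2ccc(-c3ccc(N(C)C)cc3)cc2)C(=O)C(C)C)c1`, differs from compound 3 in one place: 4-(dimethylamino)phenyl in place of 3-chlorophenyl on an aromatic carbon. Within the data shown here, none of the measured steps bears on this change; they cover a fluorine-for-trifluoromethyl exchange and the replacement of a two-carbon bridge by a direct ring-to-ring bond, not a substituent swap on a directly bound phenyl. Without a guiding step, the expectation is that compound 4 stays close to compound 3, giving an expected step of a 1.4-fold higher number from compound 3 to compound 4 (0.15 log units; within the scatter), inside or near the scatter. The estimate for compound 4 in this assay is 110 nM, with a range from 40 nM to 350 nM.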

Compound 4, half-maximal effective concentration: 57 nM
The estimate for compound 4 lay 1.9-fold (0.29 log units) above the measured number; measured number inside the range.
By their numbers in this assay, from the lowest: compounds 4, 3 and 2 (each within the scatter of the next, the first and the last beyond it); then compound 1.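

In this assay, a 1.4-fold lower number from compound 3 to compound 4 (0.13 log units; within the scatter) is within the scatter, so on this directly bound outer ring the 4-(dimethylamino)phenyl group, with its nitrogen and one hydrogen-bond acceptor, cannot be told apart from the 3-chlorophenyl group. Compound 4 also separates from the bridged compounds: a 2.1-fold lower number from compound 2 to compound 4 (0.32 log units; beyond the scatter) and a 4.7-fold lower number from compound 1 to compound 4 (0.67 log units; beyond the scatter) are both beyond the scatter, although compound 3 could not be separated from compound 2, and each of these steps exchanges the two-carbon bridge and the outer ring substituent together. Nothing measured here explains this result.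

The compounds shown do not separate the exchange of chlorine for dimethylamino from the change of ring position, which 4-chlorophenyl or 3-(dimethylamino)phenyl would do. They also leave open how a carboxylic acid in place of the methyl ester would read in this assay.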